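Pyridinyl for methylisoxazolyl on the sulfonamide nitrogen

The source may report more compounds than this note shows. Statements on the series, on what has been measured and on what is new or still open speak of the compounds shown alone.

Of the compounds shown here, two carry numbers so far. Compound 1 `Cc1ccc(C(/C=C/c2ccc(F)cc2)=N\Nc2nncc3ccccc23)cc1` gives 5.4 nM in a functional assay on MDA-MB-435 cells (Homo sapiens) for antiproliferative activity, read by sulforhodamine B assay, with a stated time of 72 h; a higher number here means a weaker inhibitor, a lower number a stronger inhibitor. Compound 2 `Cc1cc(NS(=O)(=O)c2ccc(Nc3nncc4ccccc34)cc2)no1` gives 27 nM in this assay and so stands at the higher of the two numbers; the gap down to compound 1 lies beyond the usual scatter, so compound 2 is the weaker of the pair.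

Compound 3 `O=S(=O)(Nc1ccccn1)c1ccc(Nc2nncc3ccccc23)cc1` has not been measured. Compared with compound 2 it carries pyridin-2-yl in place of 5-methyl-1,2-oxazol-3-yl on a sulfonamide nitrogen. Within the data shown here, no pair of measured compounds differs in a single place, so nothing shows how large such a swap on the sulfonamide nitrogen runs. The expectation is a small step, none beyond the scatter, with no firm direction. Compound 3 is estimated at 30 nM in this assay, within a range of 10 nM to 90 nM. The estimated change is a 1.1-fold higher number from compound 2 to compound 3 (0.05 log units; within the scatter).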

Compound 3, half-maximal inhibitory concentration: 36 nM
Compound 3: the middle estimate sits 1.2-fold (0.08 log units) below what was measured, within the range that was stated.
By their numbers in this assay, from the lowest: compound 1; then compounds 2 and 3 (each within the scatter of the next).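

Pyridin-2-yl in place of 5-methyl-1,2-oxazol-3-yl on a sulfonamide nitrogen gives a 1.3-fold higher number from compound 2 to compound 3 (0.12 log units; within the scatter) in this assay, the first single-place step in the series. At this position, a six-membered aromatic ring with 1 hetero atom and a five-membered aromatic ring with 2 hetero atoms therefore cannot be told apart in this read-out. No measurement at hand bears on what lies behind this match.

From the compounds shown here alone, whether the same holds for a non-aromatic group on that nitrogen, such as an n-butyl chain, or for a pyridine ring carrying an amine or a carboxylic acid, remains open. Compound 1 differs from compound 2 and compound 3 in more than one place, so the sulfonamide step says nothing about its lower number.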